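Acetamido to methanesulfonamido on the amino-bearing aryl

This account rests on a few compounds, and the source may have more. Where it says the series, first, only, none or still open, it means among the compounds named here.

In a functional assay on MCF7 cells (Homo sapiens) for cytotoxicity, read by MTT assay, with a stated time of 48 h (on this read-out higher numbers stand for weaker inhibition and lower numbers for stronger inhibition), compound 1 `COc1ccc(N)cc1-c1cnc2[nH]cc(-c3ccncc3)c2c1` gives 5400 nM and compound 2 `CC(=O)Nc1cccc(-c2cnc3[nH]cc(-c4ccncc4)c3c2)c1` gives 9100 nM. Compound 3 `CC(=O)Nc1cc(N)cc(-c2cnc3[nH]cc(-c4ccncc4)c3c2)c1` reaches only a limit of this assay, > 30000 nM. So compound 3 stands without a number, while compound 1 and compound 2 carry numbers; the one measured step that leads to it, an at least 3.2-fold higher number from compound 2 to compound 3 (0.51 log units; beyond the scatter), is beyond the scatter, and its value is the single one sitting at the limit of > 30000 nM in this assay, at which 1 of the 3 values shown sits. Compound 4 `CS(=O)(=O)Nc1cc(N)cc(-c2cnc3[nH]cc(-c4ccncc4)c3c2)c1` is the next member. Compared with compound 3 the change is methylsulfonyl in place of acetyl on a nitrogen on an aromatic ring; cut one bond further out it reads acetamido to methanesulfonamido. Going by the values given here, no measured pair differs by the acetyl to methylsulfonyl exchange, and compound 1 and compound 2 differ from compound 3 in other places, so none of the measured steps bears directly on this change. Among the compounds with values here, what is known is only that compound 3 itself sits at the limit and that the amino group tied to an at least 3.2-fold higher number from compound 2 to compound 3 (0.51 log units; beyond the scatter) is kept in compound 4. Compound 4 is therefore expected to remain near the limit, and the expected step of a number no higher from compound 3 to compound 4 (the limit leaves the size open) is taken as none beyond the scatter. For compound 4 the estimate in this assay is 30000 nM, between 10000 nM and 100000 nM.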

Compound 4, half-maximal inhibitory concentration: > 30000 nM
Compound 4 was reported as a limit; the forecaster's own chance of this, stated with the estimate: 65%; the middle value lies on the limit itself.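

In this assay compound 3 gives > 30000 nM, a limit and not a number. Compound 4 gives > 30000 nM, also a limit, so no step can be read between compound 3 and compound 4: the limit of > 30000 nM in this assay, at which 2 of the 4 values shown sit.

The compounds shown leave open how methylsulfonyl and acetyl on a nitrogen on an aromatic ring compare where this assay returns numbers.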